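The source may report more compounds than this note shows. Statements on the series, on what has been measured and on what is new or still open speak of the compounds shown alone.

Measured so far:
compound 1, `COc1ccc2cc(-c3ccccc3)c(O)nc2c1`: 10000 nM
compound 2, `COc1ccc(-c2cc3c(OC)cc(OC)cc3n(C)c2=O)cc1`: 10000 nM

Both measured compounds stand at the same reading in a functional assay on A549 cells (Homo sapiens) for cytotoxicity, read by colorimetric assay and MTT assay; on this read-out higher numbers stand for weaker inhibition and lower numbers for stronger inhibition. Compound 1 gives 10000 nM and compound 2 gives 10000 nM, so compound 2 is level with compound 1 at the digits recorded, the two values lying within the scatter of each other. Nothing in these two numbers separates one core substitution pattern from the other.

The next compound, compound 3, `CCOC(=O)Cn1c(=O)c(-c2ccc(OC)cc2)cc2c(OC)cc(OC)cc21`, has not yet been tested in this assay. It differs from compound 2 in one place: ethoxycarbonyl in place of hydrogen on a saturated chain carbon bound to an aromatic nitrogen. Within the data shown here, no step between measured compounds isolates a change of this kind, so the size of its effect is unknown from the data at hand.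

Among the measured compounds shown here, with compound 1 and compound 2 both at the same reading, and no step to guide the direction, the expectation for compound 3 is a step of no change at the digits printed from compound 2 to compound 3 (within the scatter), that is, none beyond the scatter. Compound 3 is therefore estimated at 10000 nM, within 4000 nM to 25000 nM.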

Compound 3, half-maximal inhibitory concentration: 10000 nM
For compound 3 middle estimate and measured number coincide at the digits printed; measured number inside the range.
By their numbers in this assay, from the lowest: compounds 1, 2 and 3 (each within the scatter of the next).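

In this assay the series now has its first step at a single place: ethoxycarbonyl in place of hydrogen on a saturated chain carbon bound to an aromatic nitrogen gives no change at the digits printed from compound 2 to compound 3 (within the scatter) and nothing more. This place on the shared core therefore takes an added group of this size, with no ring, one double bond outside aromatic rings and two hydrogen-bond acceptors, without a shift in the reading, something the earlier pair could not show, as those two compounds differ in more than one place. No measurement at hand bears on why the reading holds.

Still open, on these data alone, is whether the reading would hold with a free carboxylic acid in place of the ethyl ester, with an amine on the same chain, or with a longer chain at this place. With all three compounds printed at one value, the compounds shown also leave open which change on the shared core, if any, would move the reading in either direction.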